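Thiophen-3-yl in Place of 1-Benzofuran-2-yl on Two Cores

This account rests on a few compounds, and the source may have more. Where it says the series, first, only, none or still open, it means among the compounds named here.

Compound 1 `Cc1ncnc2c1c(-c1cc3ccccc3o1)cn2[C@@H]1O[C@H](CO)[C@@H](O)[C@H]1O` and compound 3 `Cc1ncnc2c1c(-c1ccsc1)cn2[C@@H]1O[C@H](CO)[C@@H](O)[C@H]1O` share one core and differ in a single place: thiophen-3-yl in place of 1-benzofuran-2-yl on an aromatic carbon. In an ADME assay on BJ cells (Homo sapiens), read by MTT assay, with a stated time of 72 h (a lower number here means a stronger inhibitor, a higher number a weaker inhibitor), compound 1 gives 93900 nM. In this assay compound 3 gives 96900 nM. The step between them is a 1.0-fold higher number from compound 1 to compound 3 (0.01 log units; within the scatter), so the two values cannot be told apart. Compound 2 `Cc1nc(N)c2c(-c3cc4ccccc4o3)cn([C@@H]3O[C@H](CO)[C@@H](O)[C@H]3O)c2n1` sits on a second core; the difference between the two cores is not broken down here. In this assay compound 2 reaches only a limit, > 100000 nM. That limit is the limit of > 100000 nM in this assay, at which 1 of the 3 values shown sits. Compound 4 `Cc1nc(N)c2c(-c3ccsc3)cn([C@@H]3O[C@H](CO)[C@@H](O)[C@H]3O)c2n1` has not yet been measured. It stands to compound 2 exactly as compound 3 stands to compound 1, the same change at the same place: thiophen-3-yl in place of 1-benzofuran-2-yl on an aromatic carbon. The step from compound 2 to compound 4 is expected to be a step that the limit leaves unreadable from compound 2 to compound 4. That expectation rests on compound 1 and compound 3, whose step was a 1.0-fold higher number from compound 1 to compound 3 (0.01 log units; within the scatter). Compound 4 is therefore expected to give about 110000 nM in this assay. Its estimated range runs from 55000 nM to 250000 nM, and the result may again be reported only as a limit.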

Compound 4, half-maximal inhibitory concentration: > 100000 nM
Compound 4 ended at the assay's limit; the forecaster's own chance of this, stated with the estimate: 70%; the middle value does not contradict the limit.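

In this assay, for the compounds shown here, compound 4 ends at a limit, as compound 2 does, so no step between these two compounds can be read: the limit of > 100000 nM in this assay, at which 2 of the 4 values shown sit. The compounds shown leave open what thiophen-3-yl in place of 1-benzofuran-2-yl does on the core of compound 2.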